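From methoxy to fluoro at an assay limit

The source may hold more compounds than are shown below. What is called first, only, known or untested is meant among the compounds shown, and "the series" means these compounds.

Compound 1 `CCOC(=O)c1c(-c2cccc(-c3ccccc3)c2)[nH]c2cc(OC)c(OC)cc2c1=O` gives > 21500 nM (a limit)
Compound 2 `CCOC(=O)c1c(-c2cccc(OC)c2)[nH]c2cc(OC)c(OC)cc2c1=O` gives > 21500 nM (a limit)
Compound 3 `CCOC(=O)c1c(-c2cccc(-c3ccccc3)c2)[nH]c2cc(Cl)c(OC)cc2c1=O` gives > 21500 nM (a limit)

In an ADME assay on Raji cells (Homo sapiens) for cytotoxicity, read by luminescence, with a stated time of 72 h (a lower number here means that less compound is needed, a higher number that more compound is needed for the effect), compound 1 stands at > 21500 nM which is a limit and not a number. The same holds for the other two compounds, so all the evidence is the limit of > 21500 nM in this assay, at which 3 of the 3 values shown sit, and gives no measured number at all.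

Compound 4 `CCOC(=O)c1c(-c2cccc(-c3ccccc3)c2)[nH]c2cc(OC)c(F)cc2c1=O` has not been measured. It carries fluoro in place of methoxy on an aromatic carbon.

The closest measured change is chloro in place of methoxy, which gave a step that the two limits leave unreadable from compound 1 to compound 3 and so shows no size. Methoxy in place of phenyl gave a step that the two limits leave unreadable from compound 1 to compound 2 and shows no size either.

Neither step points to a shift in this assay beyond the scatter, and neither gives a direction. The expected change is therefore a step that the limit leaves unreadable from compound 1 to compound 4 as an estimate only. Compound 4 is estimated at 30000 nM with an expected range from 15000 nM to 60000 nM and will most likely be reported only as a limit again.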

Compound 4, half-maximal effective concentration: > 21500 nM
Compound 4 was reported as a limit; the forecaster's own chance of this, stated with the estimate: 85%; the middle value lies beyond the limit too.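

In this assay compound 4 gives > 21500 nM, which is a limit and not a number. Among these compounds, compound 1 is also only a limit, so no step between compound 1 and compound 4 can be read. Whether compounds 1 to 4 truly differ in this assay stays open, as all that is shown is: the limit of > 21500 nM in this assay, at which 4 of the 4 values shown sit.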